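The compounds below may be only part of what the source reports. "The series", "measured", "known", "first", "only" and "open" are said of these compounds alone.

Compound 1 `CC1(C)OC(=O)C(=CNc2cccc([N+](=O)[O-])c2)C(=O)O1` was tested in an ADME assay on MT4 cells (Homo sapiens) for cytotoxicity, read by MTT assay, with a stated time of 4 days (a higher number here means that more compound is tolerated, a lower number that less compound is tolerated), where compound 1 gives only a limit of > 251000 nM rather than a measured number. Among the values shown, compound 1 sits at the limit of > 251000 nM in this assay, at which 1 of the 3 values shown sits. Compound 2 `CC1(C)OC(=O)C(=CNc2ccc([N+](=O)[O-])cc2)C(=O)O1` likewise gives only a limit in this assay, > 21200 nM. For the measured compounds named here, compound 3 `CC1(C)OC(=O)C(=CNc2ccccc2-c2nc3ccccc3s2)C(=O)O1` is the one compound with a number, giving 41600 nM in this assay. Compound 4 `CC1(C)OC(=O)C(=CNc2cccc(-c3nc4ccccc4s3)c2)C(=O)O1` differs from compound 1 by 1,3-benzothiazol-2-yl in place of nitro on an aromatic carbon. Going by the values given here, no pair of measured compounds differs in one place, so this step has no direct precedent, but compound 3 carries the same entering group and gives 41600 nM, which guides the expectation. For compound 4 the expected step is an at least 6.2-fold lower number from compound 1 to compound 4 (0.79 log units; beyond the scatter), toward a lower tolerated concentration. The estimate for compound 4 is 40000 nM, between 15000 nM and 120000 nM.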

Compound 4, half-maximal cytotoxic concentration: > 190000 nM
Compound 4: a limit, no number (the forecaster's own chance of this, stated with the estimate: 30%); middle value at least 4.7-fold (0.67 log units) from the limit.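

In this assay compound 1 and compound 4 both give only limits, so the step between them cannot be read. On these data alone, whether 1,3-benzothiazol-2-yl in place of nitro changes the tolerated concentration at all remains open.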